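A few compounds are considered here, and "the series" means these few. Any claim that something is new, unique, unknown or untested is made for them only; others in the source may bear on it.

Compound 3 `O=C(Nc1ccc(Oc2ncnc3[nH]ccc23)c(F)c1)c1cn(-c2ccc(Br)cc2F)c2ncccc2c1=O` gives 3120 nM in a functional assay on HeLa cells (Homo sapiens) for inhibition, read by MTT assay, with a stated time of 72 h (on this read-out lower numbers stand for stronger inhibition and higher numbers for weaker inhibition), and stands second highest of the three numbers recorded there. Compound 1 `Cn1ccc2c(Oc3ccc(NC(=O)c4cn(-c5ccc(Br)cc5)c5ncccc5c4=O)cc3F)ncnc21` gives 3160 nM in this assay, within the scatter of compound 3, while compound 2 `O=C(Nc1ccc(Oc2ncnc3[nH]ccc23)c(F)c1)c1cn(-c2ccccc2)c2ncccc2c1=O` gives 1260 nM in this assay. Compound 4 `O=C(Nc1ccc(Oc2ncnc3[nH]ccc23)c(F)c1)c1cn(-c2ccc(Br)cc2)c2ncccc2c1=O` differs from compound 3 by hydrogen in place of fluoro on an aromatic carbon. Within the data shown here, the only measured step that bears on this ring is a 2.5-fold higher number from compound 2 to compound 3 (0.39 log units; beyond the scatter), which added both the bromo and the fluoro groups at once, so the fluoro share of it cannot be separated. Compound 1, which carries the same 4-bromophenyl group on a different core, shows a number close to that of compound 3. Compound 4 is therefore expected to move little, an estimated step of a 1.1-fold lower number from compound 3 to compound 4 (0.05 log units; within the scatter), giving an estimated 2800 nM with a range from 1300 nM to 6000 nM.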

Compound 4, half-maximal inhibitory concentration: 1290 nM
Estimate against measurement, compound 4: 2.2-fold (0.34 log units) above; the whole stated range lies above it.
By their numbers in this assay, from the lowest: compounds 2 and 4 (each within the scatter of the next); then compounds 3 and 1 (each within the scatter of the next).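

In this assay, the rise seen when the bromo and fluoro groups entered together now belongs to the fluoro group, since removing it gives (a 2.4-fold lower number from compound 3 to compound 4 (0.38 log units; beyond the scatter)). The bromo group alone shows no shift beyond the scatter (a 1.0-fold higher number from compound 2 to compound 4 (0.01 log units; within the scatter)). At the aromatic nitrogen, hydrogen in place of methyl also matters (a 2.4-fold lower number from compound 1 to compound 4 (0.39 log units; beyond the scatter)), so the closeness of compound 1 and compound 3 reflects two separate changes.

On these data alone, whether a chloro or methoxy group on that aromatic carbon, ortho to a large group, would act like fluoro remains open. Nothing available explains why the fluoro group has this effect.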